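Adding a chloro to the aryl ring of compound 2

The source may hold more compounds than are shown below. What is called first, only, known or untested is meant among the compounds shown, and "the series" means these compounds.

Three compounds sharing a core in which a vinyl ketone carries a sulfur-linked group have been measured in a functional assay on DU-145 cells (Homo sapiens) for inhibition, read by trypan blue exclusion, with a stated time of 96 h; on this read-out higher numbers stand for weaker inhibition of growth and lower numbers for stronger inhibition of growth. Compound 1 `O=C(O)c1ccc(C(=O)/C(=C\c2ccc(F)c([N+](=O)[O-])c2)SCc2ccc(Cl)cc2)cc1` gives 50000 nM, and compound 3 `Cc1ccsc1/C=C(/SCc1ccc(F)cc1)C(=O)c1ccc(Br)cc1` gives 50000 nM. Compound 2 `O=C(/C(=C\c1ccc(Cl)cc1)Sc1ccc(Br)cc1)c1ccc(Br)cc1`, with its value of 1000 nM, has the lowest number of the three; the gaps to compound 1 and to compound 3 are each beyond the usual scatter of this assay, so compound 2 stands clearly as the strongest growth inhibitor among the measured compounds.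

Compound 4 `O=C(/C(=C\c1ccc(Cl)cc1Cl)Sc1ccc(Br)cc1)c1ccc(Br)cc1` has not yet been measured. It differs from compound 2 in a single place: chloro in place of hydrogen on an aromatic carbon. Put another way, the 4-chlorophenyl on one end of the core becomes a 2,4-dichlorophenyl.

Within the data shown here, no pair of measured compounds differs in only one place, so there is no directly comparable step to lean on. The change is small, one heavy atom entering on an aromatic carbon, and in this assay such an addition would most plausibly give a step within the scatter, in either direction. Compound 4 is therefore expected to land close to compound 2, with the step of a 1.5-fold higher number from compound 2 to compound 4 (0.18 log units; within the scatter) estimated as small. The estimated value for compound 4 is 1500 nM, within a range from 300 nM to 8000 nM.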

Compound 4, concentration for 50% growth inhibition: 1000 nM
For compound 4 the middle estimate is 1.5-fold (0.18 log units) above the measured one, within the range that was stated.
By their numbers in this assay, from the lowest: compounds 2 and 4 (each within the scatter of the next); then compounds 1 and 3 (each within the scatter of the next).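

Among these compounds, this is the first comparison between two compounds that differ in one place, which the earlier compounds, each differing from the others in several places, could not offer. In this assay, putting a chloro on the aromatic carbon ortho to a large group and meta to the existing chloro group, turning the 4-chlorophenyl into a 2,4-dichlorophenyl, gives no change at the digits printed from compound 2 to compound 4 (within the scatter), so this position accepts one added chlorine atom without a measurable loss of growth inhibition in these cells. Nothing measured here explains why the number stays where it does.

Among the compounds shown here, this single comparison covers only one group at one position, so it remains open whether an amine, a hydroxyl or a methoxy group in that same place would also leave growth inhibition intact. For the compounds shown here, it is equally open whether a chloro would be accepted in the same way on the same ring of a compound with a different sulfur-linked group, such as the one in compound 1 or compound 3.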